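The source may report more compounds than this note shows. Statements on the series, on what has been measured and on what is new or still open speak of the compounds shown alone.

Measured so far in an ADME assay on MDBK cells (Bos taurus) for cytotoxicity; on this read-out higher numbers stand for lower toxicity in this test and lower numbers for higher toxicity in this test:
compound 1 `Fc1cccc(F)c1-c1nc2ccn(Cc3ccccc3)cc-2n1`: > 100000 nM
compound 2 `c1ccc(Cn2ccc3nc(-c4ccccc4)nc-3c2)cc1`: > 100000 nM
compound 3 `COc1cccc(Cn2ccc3nc(-c4ccccc4)nc-3c2)c1`: > 100000 nM

Compound 3 reads > 100000 nM, which is a limit of the assay and not a number. Among the compounds with values here, it has no measured position of its own, and the series so far offers only (the limit of > 100000 nM in this assay, at which 3 of the 3 values shown sit).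

The next compound is compound 4 `Fc1ccc(Cn2ccc3nc(-c4ccccc4)nc-3c2)cc1`, which carries 4-fluorophenyl in place of 3-methoxyphenyl on a saturated chain carbon bound to an aromatic nitrogen.

Within the data shown here, two measured steps bear on this change. The nearer is a step that the two limits leave unreadable from compound 2 to compound 3, and the other is a step that the two limits leave unreadable from compound 1 to compound 2. Neither gives a size to carry over, so no step beyond the scatter is expected in this assay, and no direction is expected either. The estimated step is a number no higher from compound 3 to compound 4 (the limit leaves the size open), and it is expected to stay within the scatter. A report of the same limit is the most likely outcome. For compound 4 the estimated value is 100000 nM, with an expected range from 50000 nM to 200000 nM.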

Compound 4, half-maximal cytotoxic concentration: > 100000 nM
Compound 4 was reported as a limit (the forecaster's own chance of this, stated with the estimate: 85%); the middle value sits exactly at the limit.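

No step from compound 2 or compound 3 to compound 4 can be read in this assay, and every value remains a limit of the assay, not a number: the limit of > 100000 nM in this assay, at which 4 of the 4 values shown sit.

The compounds shown leave open whether any change on the shared core shifts this read-out, and in which direction.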